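Triazole substituent swap: octyl to trimethoxyphenyl

This account rests on a few compounds, and the source may have more. Where it says the series, first, only, none or still open, it means among the compounds named here.

Measured compounds in a functional assay on HeLa cells (Homo sapiens) for antiproliferative activity, read by sulforhodamine B assay, with a stated time of 48 h; a lower number here means a stronger inhibitor of growth, a higher number a weaker inhibitor of growth:
- compound 1 `O=C(Cn1cc(COc2nc(-c3ccccc3)nc3nc(C(F)(F)F)ccc23)nn1)Nc1ccccc1` gives 890 nM
- compound 2 `CCCCCCCCCCn1cc(COc2nc(-c3ccccc3)nc3nc(C(F)(F)F)ccc23)nn1` gives 1040 nM
- compound 3 `CCCCCCCCn1cc(COc2nc(-c3ccccc3)nc3nc(C(F)(F)F)ccc23)nn1` gives 950 nM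

Compound 3 sits among three numbers that lie within the scatter of one another; its nearest neighbour is compound 1 and its furthest is compound 2. Compound 4 `COc1cc(-n2cc(COc3nc(-c4ccccc4)nc4nc(C(F)(F)F)ccc34)nn2)cc(OC)c1OC` differs from compound 3 in one place: 3,4,5-trimethoxyphenyl in place of octyl on an aromatic nitrogen. Within the data shown here, the only measured steps touch the same nitrogen: a 1.1-fold higher number from compound 1 to compound 3 (0.03 log units; within the scatter), a 1.2-fold higher number from compound 1 to compound 2 (0.07 log units; within the scatter) and a 1.1-fold lower number from compound 2 to compound 3 (0.04 log units; within the scatter), none beyond the scatter. Those steps swapped chains and an amide, not an aromatic ring, so the precedent is loose. Compound 4 is therefore expected near compound 3, a 1.1-fold lower number from compound 3 to compound 4 (0.02 log units; within the scatter), estimated at 900 nM within 350 nM to 2500 nM.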

Compound 4, concentration for 50% growth inhibition: 890 nM
Compound 4: the middle estimate sits 1.0-fold (0.00 log units) above what was measured, and the stated range covers the measured number.
By their numbers in this assay, from the lowest: compounds 1, 4, 3 and 2 (each within the scatter of the next).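

Until now this aromatic nitrogen had carried only chains and an amide, and in this assay a directly attached ring, 3,4,5-trimethoxyphenyl, gives a number in the same narrow band (a 1.1-fold lower number from compound 3 to compound 4 (0.03 log units; within the scatter)) (a 1.2-fold lower number from compound 2 to compound 4 (0.07 log units; within the scatter)) (no change at the digits printed from compound 1 to compound 4 (within the scatter)). At this position, the number does not separate chains from a ring carrying hydrogen-bond acceptors. No measurement here explains why these different groups give such similar numbers.

Going by these compounds, whether a methyl group, or a phenyl ring bearing an amine or a carboxylic acid, would move the number beyond the scatter stays open.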